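The compounds below may be only part of what the source reports. "The series", "measured", "known", "first", "only" and "open" are said of these compounds alone.

Measured in a functional assay on A549 cells (Homo sapiens) for cytotoxicity, read by MTT assay, with a stated time of 72 h; a higher number here means a weaker inhibitor, a lower number a stronger inhibitor:
compound 1 `C#Cc1cccc(Nc2ncnc3oc(C)c(C(=O)OCC)c23)c1`: > 1000000 nM (a limit, not a number)
compound 2 `Cc1oc2ncnc(Nc3ccccc3)c2c1C(=O)O`: 191000 nM

Compound 1 gives no number, only a limit: the limit of > 1000000 nM in this assay, at which 1 of the 2 values shown sits. Compound 3 `CCOC(=O)c1c(C)oc2ncnc(Nc3cccc(Cl)c3)c12` is still unmeasured. It has chloro in place of ethynyl on an aromatic carbon, meta to a large group, going from 3-ethynylphenyl to 3-chlorophenyl: chloro in place of ethynyl on an aromatic carbon. For the measured compounds named here, no measured step shows this change, so any expectation in this assay is loose. A number within reach is expected, since compound 2 reads 191000 nM. The expected step of an at least 3.3-fold lower number from compound 1 to compound 3 (0.52 log units; beyond the scatter) points towards a stronger inhibitor, though compound 3 may also stop at a limit. For compound 3 the estimated value is 300000 nM, with an expected range of 60000 nM to 1000000 nM.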

Compound 3, half-maximal inhibitory concentration: > 1000000 nM
Compound 3: a limit, no number; the forecaster's own chance of this, stated with the estimate: 35%; at least 3.3-fold (0.52 log units) between middle value and limit.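

No step can be read between compound 1 and compound 3: each gives only a limit, not a number. The compounds shown leave open what chloro in place of ethynyl on an aromatic carbon does to cytotoxicity.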